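Naphthalen-1-yl Replaces 3,5-Dichlorophenyl on the Ring Amine

The source may report more compounds than this note shows. Statements on the series, on what has been measured and on what is new or still open speak of the compounds shown alone.

Two compounds built on a shared core have been examined in a functional assay on CHO cells with adenosine receptor A1 (Homo sapiens) as the target, read by cAMP accumulation and immunoassay, with a stated time of 6 min, tested at 0.1 uM; a higher number here means a weaker effect of the compound at the concentration tested, a lower number a stronger effect. Compound 1, `Nc1scc(CN2CCN(c3cc(Cl)cc(Cl)c3)CC2)c1C(=O)c1ccc(Cl)cc1`, gives -22% in this assay. Compound 2, `Nc1scc(CN2CCN(c3c(F)cccc3F)CC2)c1C(=O)c1cccc(C(F)(F)F)c1`, gives 1.3% in this assay. Compound 1 therefore stands at the lower of the two numbers, and compound 2 lies above it by a margin beyond the usual scatter of repeated measurements.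

Compound 3, `Nc1scc(CN2CCN(c3cccc4ccccc34)CC2)c1C(=O)c1ccc(Cl)cc1`, has not yet been measured in this assay. It differs from compound 1 in a single place: naphthalen-1-yl in place of 3,5-dichlorophenyl on an amine nitrogen in a ring. Within the data shown here, no step between measured compounds that differ in one place is available, so any expectation rests on the two values alone, both of which sit near the low end of the scale. The step of a number 14 percentage points higher from compound 1 to compound 3 (beyond the scatter) is expected to be small, toward a less negative reading, and may well fall within the scatter. Compound 3 is estimated at -8%, within a range from -30% to 15%.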

Compound 3, a percentage reported as activity, at one concentration (the size of the read-out at that concentration, not a potency): 0%
The estimate for compound 3 lay 8 percentage points below the measured number; the measured number falls inside the stated range.
By their numbers in this assay, from the lowest: compound 1; then compounds 3 and 2 (each within the scatter of the next).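

In this assay, among these compounds, naphthalen-1-yl in place of 3,5-dichlorophenyl on the amine nitrogen in a ring gives a modest step, a number 22 percentage points higher from compound 1 to compound 3 (beyond the scatter) and this is the first comparison here between compounds that differ in one place. It shows that the reading responds to the group at this position: compound 3, with two six-membered aromatic rings of carbon only and no chlorine, gives 0% and so has a weaker effect at the concentration tested than compound 1. Nothing measured here accounts for the step.

The single change swaps the chlorine atoms and adds a second ring at once, so the compounds shown do not separate these two parts of the step. On these data alone, a plain phenyl group or naphthalen-2-yl at this position would bear on that, and whether the step carries over to other groups on the carbonyl remains open.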